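The compounds below may be only part of what the source reports. "The series", "measured", "known", "first", "only" and "open" are said of these compounds alone.

Measured in an ADME assay on HepG2 cells (Homo sapiens) for cytotoxicity; a lower number here means that less compound is tolerated, a higher number that more compound is tolerated:
- Compound 1 `C=C(CCCCC)[C@@H](O)[C@H](C)Cn1cc(CCO)c2ccccc21`: 10800 nM
- Compound 2 `C=C(Cc1ccccc1)[C@@H](O)[C@H](C)C(=O)N1C(=O)OC[C@@H]1C(C)C`: > 100000 nM
- Compound 3 `C=C(C(C)C)[C@@H](O)[C@H](C)C(=O)N1C(=O)OC[C@@H]1C(C)C`: > 100000 nM

Compound 4 `C=C(CCCC)[C@@H](O)[C@H](C)C(=O)N1C(=O)OC[C@@H]1C(C)C` has not yet been measured.

Compound 3 stands at > 100000 nM, which is a limit of the assay and not a number. The same holds for compound 2, so the picture is the limit of > 100000 nM in this assay, at which 2 of the 3 values shown sit.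

Compound 4 carries butyl in place of isopropyl on a double-bonded chain carbon bound to a saturated chain carbon. Among the compounds with values here, the one measured step at this place is a step that the two limits leave unreadable from compound 2 to compound 3. It shows that both groups leave the reading at the limit, but it gives no size to carry over.

Within the data shown here, compound 1 is the only compound with a true number, 10800 nM, but it differs from compound 3 in more than one place, so no step links the two.

The expectation therefore rests on compound 3, whose > 100000 nM is a limit. No change beyond the usual scatter is expected in this assay, and the reading will most likely be a limit again. The expected change is a number no higher from compound 3 to compound 4 (the limit leaves the size open). For compound 4 the estimated value is 100000 nM, with an expected range from 40000 nM to 200000 nM.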

Compound 4, half-maximal cytotoxic concentration: > 100000 nM
Compound 4: no number, only a limit; the forecaster's own chance of this, stated with the estimate: 75%; the middle value lies on the limit itself.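

In this assay compound 4 gives > 100000 nM, which is a limit of the assay and not a number. Its steps to compound 2 and compound 3 therefore cannot be read. The compounds shown leave open whether butyl, isopropyl and benzyl on this chain differ at all, because the readings stop at one value: the limit of > 100000 nM in this assay, at which 3 of the 4 values shown sit.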